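Methyl Added Near the Core in Two Related Pairs

The source may report more compounds than this note shows. Statements on the series, on what has been measured and on what is new or still open speak of the compounds shown alone.

Compound 1 `CCC1(c2ccccc2)CC(=O)C(C(CC(=O)c2ccc(-c3ccc(Br)cc3)cc2)c2ccccc2)=C(O)O1` is measured in a functional assay on SK-OV-3 cells (Homo sapiens) for inhibition, with a stated time of 72 h (on this read-out lower numbers stand for stronger inhibition and higher numbers for weaker inhibition), and compound 1 gives 5740 nM. Compound 2 `CCCC1(c2ccccc2)CC(=O)C(C(CC(=O)c2ccc(-c3ccc(Br)cc3)cc2)c2ccccc2)=C(O)O1` carries one change from compound 1, (methyl in place of hydrogen on a saturated chain carbon, two bonds along the chain from a saturated ring carbon). For compound 2 this assay reports only a limit, > 10000 nM, the point (the limit of > 10000 nM in this assay, at which 1 of the 3 values shown sits). The step is an at least 1.7-fold higher number from compound 1 to compound 2 (0.24 log units; that floor lies within the scatter). Compound 3 `CC1(c2ccccc2)CC(=O)C(C2CC(c3ccc(-c4ccc(Br)cc4)cc3)Cc3ccccc32)=C(O)O1` has a different core from compound 1, and that difference is not broken down here; in this assay compound 3 gives 1800 nM. Compound 4 `CCC1(c2ccccc2)CC(=O)C(C2CC(c3ccc(-c4ccc(Br)cc4)cc3)Cc3ccccc32)=C(O)O1` is not yet measured; from compound 3 it differs by methyl in place of hydrogen on a saturated chain carbon bound to a saturated ring carbon. The place is not the same as in the first pair, where the carbon sits two bonds along the chain from a saturated ring carbon rather than bound to it, so this is the same kind of change. The step from compound 3 to compound 4 is expected to be a 1.8-fold higher number from compound 3 to compound 4 (0.25 log units; within the scatter), resting on the measured step of an at least 1.7-fold higher number from compound 1 to compound 2 (0.24 log units; that floor lies within the scatter) in the first pair. Compound 4 is therefore estimated at 3200 nM, between 1300 nM and 8000 nM.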

Compound 4, half-maximal inhibitory concentration: > 10000 nM
Compound 4: no number, only a limit (the forecaster's own chance of this, stated with the estimate: 10%); middle value at least 3.1-fold (0.49 log units) from the limit.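

In this assay compound 4 is reported only as a limit, > 10000 nM. This gives an at least 5.5-fold higher number from compound 3 to compound 4 (0.74 log units; beyond the scatter), so on the core of compound 3 the added methyl goes with weaker inhibition, while the floor of the earlier step on the core of compound 1 does not pass the scatter. The result therefore gives no measure of how far the change carries from one core to the other: the same change on two cores in this assay, an at least 1.7-fold higher number (0.24 log units; that floor lies within the scatter) from compound 1 to compound 2 and an at least 5.5-fold higher number (0.74 log units; beyond the scatter) from compound 3 to compound 4; the limit leaves it open whether they differ

The compounds shown leave open the true size of either step, since neither compound 2 nor compound 4 has a number. They also leave open how an amine or a carboxylic acid in place of this methyl would read in this assay.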